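Bromo to Methyl on the Anilino Ring of Compound 3

The source may report more compounds than this note shows. Statements on the series, on what has been measured and on what is new or still open speak of the compounds shown alone.

Compound 1 `Cc1cccc(Nc2ncnc3oc(C)c(C(=O)O)c23)c1` gives 57500 nM in a functional assay on MCF7 cells (Homo sapiens) for cytotoxicity, read by MTT assay, with a stated time of 72 h; a higher number here means a weaker inhibitor, a lower number a stronger inhibitor.
Compound 2 `CCOC(=O)c1c(C)oc2ncnc(Nc3cccc(Br)c3)c12` reaches only the assay limit, > 1000000 nM, in this assay.
Compound 3 `Cc1oc2ncnc(Nc3cccc(Br)c3)c2c1CO` gives 11000 nM in this assay.

Among the two numbers obtained, compound 3 carries the lower one, and compound 1 the higher. Going by the values given here, only one measured step exists: an at least 90-fold lower number from compound 2 to compound 3 (1.95 log units; beyond the scatter), a large change at the hydroxymethyl position, touching (the limit of > 1000000 nM in this assay, at which 1 of the 3 values shown sits). Compound 4 `Cc1cccc(Nc2ncnc3oc(C)c(CO)c23)c1` differs from compound 3 by methyl in place of bromo on an aromatic carbon. Among the compounds with values here, no measured step concerns that exchange, so nothing here supports a shift beyond the scatter in this assay, and compound 4 is expected to sit close to compound 3. The estimate for compound 4 is 15000 nM, between 5000 nM and 45000 nM, an expected step of a 1.4-fold higher number from compound 3 to compound 4 (0.13 log units; within the scatter).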

Compound 4, half-maximal inhibitory concentration: 17000 nM
Beside the measured number, compound 4's estimate is 1.1-fold (0.05 log units) below it; low and high end bracket the measured number.
By their numbers in this assay, from the lowest: compounds 3 and 4 (each within the scatter of the next); then compound 1. At a limit, above all of these: compound 2.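

Methyl in place of bromo gives a 1.5-fold higher number from compound 3 to compound 4 (0.19 log units; within the scatter), so in this assay this exchange on the aromatic carbon leaves the reading unchanged within the scatter. With methyl held constant, hydroxymethyl in place of carboxy gives a 3.4-fold lower number from compound 1 to compound 4 (0.53 log units; beyond the scatter), which shows that the hydroxymethyl group also compares favourably with carboxy, not only with ethoxycarbonyl. Nothing available here explains either step.

Still open, on these data alone, is whether a methoxy group or a chlorine at the same ring position would also stay within the scatter. It is equally unclear how an amine or a longer alcohol chain would read in place of hydroxymethyl.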